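From Ethyl to Chloro on Compound 3

This account rests on a few compounds, and the source may have more. Where it says the series, first, only, none or still open, it means among the compounds named here.

Measured in a physicochemical assay for lipophilicity, using the shake flask method; a lower number here means a more polar compound, a higher number a more lipophilic compound:
- Compound 1 `CC(C)Oc1cc(Oc2ccc(S(C)(=O)=O)cc2)cc(-c2ccnc(=O)[nH]2)c1`: "not determined" (no result reported)
- Compound 2 `CC(C)Oc1cc(Oc2ccc(S(C)(=O)=O)cc2)cc(-c2cncc(=O)[nH]2)c1`: 2.27
- Compound 3 `CCc1cnc(-c2cc(Oc3ccc(S(C)(=O)=O)cc3)cc(OC(C)C)c2)[nH]c1=O`: 3.11

Only two of these compounds have a number, and compound 3 at 3.11 holds the higher one. The next structure, compound 4 `CC(C)Oc1cc(Oc2ccc(S(C)(=O)=O)cc2)cc(-c2ncc(Cl)c(=O)[nH]2)c1`, alters compound 3 in one place: chloro in place of ethyl on an aromatic carbon. In words, this is chloro in place of ethyl on an aromatic carbon.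

Just one measured step offers any guidance, and that guidance is indirect. It is a number 0.84 log units higher from compound 2 to compound 3 (beyond the scatter). For the measured compounds named here, that step exchanged a whole ring group, so it does not isolate the ethyl, and no measured compound carries chloro. The number rose there as the group grew, and here the entering group is the smaller one, so a modest fall in this assay is expected, though with wide uncertainty.

The expected change is a number 0.51 log units lower from compound 3 to compound 4 (beyond the scatter).

For compound 4 the estimate is 2.6, with an expected range from 2.1 to 3.1.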

Compound 4, distribution coefficient: 2.04
The estimate for compound 4 lay 0.56 log units above the measured number; the whole stated range lies above it.
By their numbers in this assay, from the lowest: compounds 4 and 2 (each within the scatter of the next); then compound 3.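

Moving from ethyl to chloro at this ring carbon changes one small group only, and in this assay the outcome is a number 1.07 log units lower from compound 3 to compound 4 (beyond the scatter), a large step. For the compounds shown here, the earlier step exchanged a whole ring group, so this is the first result showing that the group on this carbon alone can shift the number so far. Compared with the ring group of compound 2, the chloro-bearing ring group gives a number 0.23 log units lower from compound 2 to compound 4 (within the scatter), so these two compounds cannot be told apart in this assay.

As far as these compounds go, whether a methyl, a longer chain, a fluoro or an amine on the same carbon would land nearer compound 3 or compound 4 stays open. Nothing shown here explains the size of the step from ethyl to chloro.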